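A few compounds are considered here, and "the series" means these few. Any claim that something is new, unique, unknown or untested is made for them only; others in the source may bear on it.

Compound 1 `Cc1ccc(C2=NN(c3ccc([N+](=O)[O-])cc3)C(c3cn(-c4ccccc4)nc3-c3ccc(Cl)c(Cl)c3)C2)cc1`: in a functional assay on the whole organism (strain Wistar) for inhibition, with Rattus norvegicus as the target, read by paw edema, with stated times of 30 min and 120 min, at a dose of 50 mg/kg by the oral route (on this read-out higher numbers stand for more inhibition at the one dose given (going by the name of the read-out) and lower numbers for less inhibition), compound 1 gives 71.9%.
Compound 2 `CC(=O)N1N=C(c2ccc(C)cc2)CC1c1cn(-c2ccccc2)nc1-c1ccc(Cl)c(Cl)c1`: in this assay compound 2 gives 70.3%.
Compound 3 `Clc1ccc(C2=NN(c3ccccc3)C(c3cn(-c4ccccc4)nc3-c3ccc(Cl)c(Cl)c3)C2)cc1`: in this assay compound 3 gives 61.7%.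

Among these three, compound 3 carries the lowest number. Its gap to compound 2 lies within the scatter, so the two cannot be set in order; only the gap to compound 1 lies beyond it. Going by the values given here, the one measured step, a number 1.6 percentage points lower from compound 1 to compound 2 (within the scatter), swaps the group on the ring nitrogen and stays within the scatter, so it shows that this part of the molecule can be altered without a clear shift in this assay.

Compound 4 `Cc1ccc(C2=NN(c3ccccc3)C(c3cn(-c4ccccc4)nc3-c3ccc(Cl)c(Cl)c3)C2)cc1` is the next candidate. It differs from compound 3 in one place: methyl in place of chloro on an aromatic carbon. Among the compounds with values here, no measured pair carries this exact exchange, since compound 1 holds the 4-methylphenyl but also a different group on the ring nitrogen, so no step is available to lean on. Within the data shown here, the only guidance is that compound 1, which shares the 4-methylphenyl with compound 4, sits at the higher end of the three numbers. On that thin basis compound 4 is expected to move only a little upward, with a number 4.3 percentage points higher from compound 3 to compound 4 (within the scatter) not clearly beyond the scatter. The estimate for compound 4 in this assay is therefore 66%, with a range from 56% to 76%.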

Compound 4, a percentage reported as inhibition, in the whole organism at one dose (the size of the read-out at that dose, not a potency): 62.5%
Compound 4: the middle estimate sits 3.5 percentage points above what was measured; low and high end bracket the measured number.
By their numbers in this assay, from the lowest: compounds 3, 4, 2 and 1 (each within the scatter of the next, the first and the last beyond it).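

In this assay, going by these compounds alone, the exchange of 4-chlorophenyl for 4-methylphenyl, on an aromatic carbon para to a large group, gives a number 0.8 percentage points higher from compound 3 to compound 4 (within the scatter) and is the first direct reading at this position, where chloro and methyl cannot be told apart. On the ring nitrogen, phenyl in place of acetyl gives a number 7.8 percentage points lower from compound 2 to compound 4 (within the scatter) and hydrogen in place of nitro on the phenyl group gives a number 9.4 percentage points lower from compound 1 to compound 4 (within the scatter) and so, together with the earlier step between acetyl and 4-nitrophenyl, these readings show three groups on that nitrogen that cannot be set in order. Nothing given here bears on the reason for these readings.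

The compounds shown leave open whether a group of another kind at this position, such as a hydroxyl, an amine or a carboxylic acid, would stand apart from chloro and methyl in this assay at all. They also leave open whether a longer chain or a benzoyl group on the ring nitrogen would do so, and how the compounds would compare at other doses.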